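Sulfamoylamino to carbamoylmethyl amino on the tetralin side chain

A few compounds are considered here, and "the series" means these few. Any claim that something is new, unique, unknown or untested is made for them only; others in the source may bear on it.

Two members of the series carry numbers. Compound 1 `N#Cc1cccc(S(=O)(=O)c2ccc3c(c2)CCC[C@H]3C=N)c1` gives 0.501 nM in an assay on isolated protein for displacement of a labelled ligand from 5-hydroxytryptamine receptor 6 (Homo sapiens); a lower number here means a stronger inhibitor, a higher number a weaker inhibitor. Compound 2 `CN(C)S(=O)(=O)NC[C@@H]1CCCc2cc(S(=O)(=O)c3cccc(F)c3)ccc21` gives 2 nM in this assay, the higher of the two numbers; compound 1 sits lower by a margin beyond the scatter. Going by the values given here, no measured pair differs in a single place, so no measured step is available as a guide for the next change.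

Compound 3 `CN(CC(N)=O)C[C@@H]1CCCc2cc(S(=O)(=O)c3cccc(F)c3)ccc21` is the next candidate, and it differs from compound 2 in one exchange: (carbamoylmethyl)(methyl)amino in place of (dimethylsulfamoyl)amino on a saturated chain carbon bound to a saturated ring carbon. The (dimethylsulfamoyl)amino group leaves and the (carbamoylmethyl)(methyl)amino group enters, with one hydrogen-bond donor and two acceptors retained on each side of the change. Without a comparable measured step, only a modest movement is expected, a 1.5-fold lower number from compound 2 to compound 3 (0.19 log units; within the scatter), leaning toward a lower number but possibly within the scatter. Compound 3 is therefore estimated at 1.3 nM, with an expected range from 0.4 nM to 5 nM.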

Compound 3, inhibition constant: 1.26 nM
Compound 3: middle estimate off by 1.0-fold (0.01 log units), on the high side; the range from low to high includes it.
By their numbers in this assay, from the lowest: compound 1; then compounds 3 and 2 (each within the scatter of the next).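

In this assay, going by these compounds alone, the exchange of (dimethylsulfamoyl)amino for (carbamoylmethyl)(methyl)amino gives a 1.6-fold lower number from compound 2 to compound 3 (0.20 log units; within the scatter), the first single-place step. On a saturated chain carbon bound to a saturated ring carbon, a group with no sulfur and 6 heavy atoms can therefore stand in place of one with 7, with the same donor and acceptor counts and no change beyond the scatter. No measurement available here offers an explanation for this result.

Within the data shown here, compound 1 differs from compound 2 and compound 3 in more than one place, so no step connects its side chain or its nitrile to either of them. Open at this position is whether a carboxylic acid, a primary amine or a longer chain ending in the same carbamoyl group would stay within the scatter of compound 3.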